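This account rests on a few compounds, and the source may have more. Where it says the series, first, only, none or still open, it means among the compounds named here.

In an ADME assay on MT4 cells (Homo sapiens) for cytotoxicity, read by MTT assay, with a stated time of 4 days (on this read-out higher numbers stand for lower toxicity in this test and lower numbers for higher toxicity in this test), compound 1 `Cc1cc(C#N)cc(C)c1Oc1ccnc(S(=O)(=O)CC(=O)Nc2cccc(F)c2)n1` gives 25900 nM. Compound 2 `Cc1cc(C#N)cc(C)c1Oc1ccnc(S(=O)(=O)CC(=O)Nc2ccc(C#N)cc2F)n1` reaches only the assay limit, > 268000 nM (the limit of > 268000 nM in this assay, at which 1 of the 2 values shown sits). The step of an at least 10-fold higher number from compound 1 to compound 2 (1.01 log units; beyond the scatter) came with 4-cyano-2-fluorophenyl in place of 3-fluorophenyl on an amide-type nitrogen. Compound 3 `Cc1cc(C#N)cc(C)c1Oc1ccnc(S(=O)(=O)CC(=O)Nc2ccc([N+](=O)[O-])cc2)n1` differs from compound 2 by 4-nitrophenyl in place of 4-cyano-2-fluorophenyl on an amide-type nitrogen. Among the measured compounds shown here, only that one measured step bears on this change, and it ends at a limit, so the true size of the step into compound 2 is unknown. Compound 3 is therefore expected to stay near that limit, with a small move an at least 1.7-fold lower number from compound 2 to compound 3 (0.25 log units; that floor lies within the scatter). Compound 3 is estimated at 150000 nM, between 40000 nM and 300000 nM.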

Compound 3, half-maximal cytotoxic concentration: 59600 nM
Compound 3: middle estimate off by 2.5-fold (0.40 log units), on the high side, within the range that was stated.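

Changing the group on the amide-type nitrogen to 4-nitrophenyl gives an at least 4.4-fold lower number from compound 2 to compound 3 (0.65 log units; beyond the scatter), so a para-free reading is not needed: not every substituted phenyl here reaches the top of the range. Compound 2 stands at a limit of the assay, so that step has only a floor: the limit of > 268000 nM in this assay, at which 1 of the 3 values shown sits. Compared with 3-fluorophenyl, 4-nitrophenyl still gives a 2.3-fold higher number from compound 1 to compound 3 (0.36 log units; beyond the scatter), which places compound 3 between the other two.

Still open, as far as these compounds go, is whether the nitrile or the fluorine of 4-cyano-2-fluorophenyl matters more for the high number of compound 2. Also open, from the compounds shown here alone, is what an amine or a carboxylic acid in place of the nitro group would give.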